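The source may report more compounds than this note shows. Statements on the series, on what has been measured and on what is new or still open speak of the compounds shown alone.

Of the compounds shown here, three that share one core have been tested in a functional assay on K562 cells (Homo sapiens) for inhibition, read by fluorescence, with a stated time of 72 h; on this read-out higher numbers stand for weaker inhibition of growth and lower numbers for stronger inhibition of growth. Compound 1 `COc1cc(Nc2nc(N[C@H]3CC[C@H](N)CC3)nc3c2ncn3CCC(C)C)cc(OC)c1` gives 2500 nM. Compound 2 `CCCCCCn1cnc2c(Nc3cc(OC)cc(OC)c3)nc(N[C@H]3CC[C@H](N)CC3)nc21` gives 1900 nM, and compound 3 `CCCCCCn1cnc2c(Nc3cccc(Cl)c3)nc(N[C@H]3CC[C@H](N)CC3)nc21` gives 2300 nM. Compound 3 differs from compound 2 by 3-chlorophenyl in place of 3,5-dimethoxyphenyl on a nitrogen on an aromatic ring, a change that produced a 1.2-fold higher number from compound 2 to compound 3 (0.08 log units; within the scatter). Compound 1 differs from compound 2 by isopropyl in place of butyl on a saturated chain carbon, two bonds along the chain from an aromatic nitrogen, which produced a 1.3-fold higher number from compound 2 to compound 1 (0.12 log units; within the scatter).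

Compound 4 `CC(C)CCn1cnc2c(Nc3cccc(Cl)c3)nc(N[C@H]3CC[C@H](N)CC3)nc21` has not been measured in this assay. It differs from compound 3 by isopropyl in place of butyl on a saturated chain carbon, two bonds along the chain from an aromatic nitrogen, the same change, at the same place, as that made from compound 2 to compound 1. The expectation for compound 4 rests on the step of a 1.3-fold higher number from compound 2 to compound 1 (0.12 log units; within the scatter) and on the value of compound 3, 2300 nM. Compound 4 is therefore expected to show a step of a 1.2-fold higher number from compound 3 to compound 4 (0.09 log units; within the scatter). Compound 4 is estimated at 2800 nM, with a likely range from 1500 nM to 5500 nM.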

Compound 4, concentration for 50% growth inhibition: 1500 nM
Beside the measured number, compound 4's estimate is 1.9-fold (0.27 log units) above it; the range from low to high includes it.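

In this assay, isopropyl in place of butyl gives a 1.5-fold lower number from compound 3 to compound 4 (0.19 log units; within the scatter), and this step agrees with the earlier one on the other core: the same change on two cores in this assay, a 1.3-fold higher number (0.12 log units; within the scatter) from compound 2 to compound 1 and a 1.5-fold lower number (0.19 log units; within the scatter) from compound 3 to compound 4, 2.0-fold (0.30 log units) apart, within the scatter of two such steps. Likewise, 3-chlorophenyl in place of 3,5-dimethoxyphenyl gives a 1.7-fold lower number from compound 1 to compound 4 (0.22 log units; within the scatter), which also agrees with its earlier counterpart: the same change on two cores in this assay, a 1.2-fold higher number (0.08 log units; within the scatter) from compound 2 to compound 3 and a 1.7-fold lower number (0.22 log units; within the scatter) from compound 1 to compound 4, 2.0-fold (0.30 log units) apart, within the scatter of two such steps. Both changes therefore carry from one core to the other with no difference that can be told apart from the scatter, but since every step itself lies within the scatter, this does not show that either change has an effect that transfers.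

The compounds shown leave open whether a longer chain or a chain ending in an amine, or a carboxylic acid on the aromatic ring, would give a step beyond the scatter, and whether such a step would carry between cores.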